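This account rests on a few compounds, and the source may have more. Where it says the series, first, only, none or still open, it means among the compounds named here.

Measured compounds and values:
compound 2 `N#C[C@@]1(NC(=O)[C@@H](CC(=O)N2CCOCC2)CC2CCCCC2)CCNC1`: 123 nM
compound 3 `CN1CCC(C#N)(NC(=O)[C@@H](CC(=O)N2CCOCC2)CC2CCCCC2)CC1`: 177 nM
compound 1 `N#C[C@@]1(NC(=O)[C@@H](CC(=O)N2CCOCC2)CC2CCC(c3ccccc3)CC2)CCN(C2CCCCC2)C1`: "not determined" (no result reported)

Compound 1 stands without a number in an assay on isolated protein for inhibition of cathepsin S (Homo sapiens); on this read-out lower numbers stand for tighter binding and higher numbers for weaker binding; nothing is known of its own binding, and it serves here only as the structural starting point. Compound 2 gives 123 nM in this assay, and compound 3 gives 177 nM. Among the compounds with values here, the one measured step, a 1.4-fold higher number from compound 2 to compound 3 (0.16 log units; within the scatter), concerns the ring on the amide-type nitrogen and lies within the scatter, so the two measured compounds set a common level rather than a trend.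

Compound 4 `N#C[C@@]1(NC(=O)[C@@H](CC(=O)N2CCOCC2)CC2CCc3ccccc3C2)CCN(C2CCCCC2)C1` differs from compound 1 by 1,2,3,4-tetrahydronaphthalen-2-yl in place of 4-phenylcyclohexyl on a saturated chain carbon, two bonds along the chain from a carbonyl carbon. Within the data shown here, no measured step touches this position: compounds 2 and 3 differ from compounds 1 and 4 both at the chain substituent and at the amine ring, so neither a direction nor a size can be read off for this change. What remains is the level set by compounds 2 and 3, which carry a cyclohexyl at the same chain carbon.

Compound 4 is therefore expected to land near that level, with an estimate of 100 nM and a range of 20 nM to 500 nM.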

Compound 4, dissociation constant: 5.4 nM
Estimate against measurement, compound 4: 19-fold (1.27 log units) above; measured number below the stated range.
By their numbers in this assay, from the lowest: compound 4; then compounds 2 and 3 (each within the scatter of the next).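

No new step can be read for compound 4: compound 1 has no number in this assay and compounds 2 and 3 differ from compound 4 in more than one place. No evidence bears on this result.

The compounds shown leave open how much of the value of compound 4 belongs to the 1,2,3,4-tetrahydronaphthalen-2-yl and how much to the rest of its structure.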